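From compound 3 to a hydroxyphenyl counterpart

The compounds below may be only part of what the source reports. "The series", "measured", "known", "first", "only" and "open" are said of these compounds alone.

Compound 1 `COc1cc(NC(C)CCCNC(=O)NNC(=O)Nc2ccc(F)cc2)c2ncccc2c1`: >= 250000 nM, a limit of the assay
Compound 2 `COc1cc(NC(C)CCCNC(=O)NNC(=O)Nc2ccc(Br)cc2)c2ncccc2c1`: 231000 nM
Compound 3 `COc1cc(NC(C)CCCNC(=O)Nc2cccc(C(F)(F)F)c2)c2ncccc2c1`: 17000 nM

In a functional assay on MIA PaCa-2 cells (Homo sapiens) for inhibition, read by MTT assay, with a stated time of 72 h (a lower number here means a stronger inhibitor, a higher number a weaker inhibitor), compound 3 gives 17000 nM, the lowest number of the three. Compound 4 `COc1cc(NC(C)CCCNC(=O)NNC(=O)Nc2ccc(O)cc2)c2ncccc2c1` is still unmeasured. It differs from compound 3 as follows: ((4-hydroxyphenyl)carbamoyl)amino in place of 3-(trifluoromethyl)phenyl on an amide-type nitrogen. Two measured steps join the same kinds of group, an at least 14-fold lower number from compound 1 to compound 3 (1.16 log units; beyond the scatter) and a 14-fold lower number from compound 2 to compound 3 (1.13 log units; beyond the scatter), and both are large. Read in reverse, they point to a higher number for compound 4. For the measured compounds named here, the exchange of fluoro for bromo, an at least 1.0-fold lower number from compound 1 to compound 2 (0.03 log units; that floor lies within the scatter), stays within the scatter, but no hydroxy compound has been measured. A large rise is therefore expected, an estimated 8.8-fold higher number from compound 3 to compound 4 (0.95 log units; beyond the scatter). Compound 4 is estimated at 150000 nM, with an expected range from 50000 nM to 300000 nM.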

Compound 4, half-maximal inhibitory concentration: 142000 nM
Estimate against measurement, compound 4: 1.1-fold (0.02 log units) above; measured number inside the range.
By their numbers in this assay, from the lowest: compound 3; then compounds 4 and 2 (each within the scatter of the next). At a limit, above all of these: compound 1.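

On the amide-type nitrogen, ((4-hydroxyphenyl)carbamoyl)amino does not match 3-(trifluoromethyl)phenyl in this assay, with an 8.4-fold higher number from compound 3 to compound 4 (0.92 log units; beyond the scatter). Hydroxy in place of bromo on the aromatic carbon stays within the scatter, with a 1.6-fold lower number from compound 2 to compound 4 (0.21 log units; within the scatter), and hydroxy in place of fluoro shows only a floor, with an at least 1.7-fold lower number from compound 1 to compound 4 (0.24 log units; that floor lies within the scatter), so hydroxy is not told apart from either halogen here. The value of compound 1 is a limit: the limit of >= 250000 nM in this assay, at which 1 of the 4 values shown sits.

As far as these compounds go, what an amine or a carboxylic acid on that aromatic carbon would give remains open. So does the effect of a trifluoromethyl group there.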